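This account rests on a few compounds, and the source may have more. Where it says the series, first, only, none or still open, it means among the compounds named here.

Measured compounds:
compound 1 `ClCc1cccc(Cn2cnc3ncnc(Cl)c32)c1`: 2180 nM
compound 2 `ClCc1ccccc1Cn1cnc2ncnc(Cl)c21`: 11200 nM
compound 3 `ClCc1cccc(Cn2cnc3nc(Cl)nc(Cl)c32)c1`: 2180 nM

Of the compounds shown here, three have been tested in a functional assay on HOP-62 cells (Homo sapiens) for cytotoxicity, read by sulforhodamine B assay, with a stated time of 48 h; on this read-out lower numbers stand for stronger inhibition of growth and higher numbers for weaker inhibition of growth. Compound 1 `ClCc1cccc(Cn2cnc3ncnc(Cl)c32)c1` gives 2180 nM. Compound 2 `ClCc1ccccc1Cn1cnc2ncnc(Cl)c21` shares its atoms with compound 1 but joins them differently; the difference between the two cores is not broken down here. In this assay compound 2 gives 11200 nM, the highest of the three numbers and beyond the scatter from both other compounds. Compound 3 `ClCc1cccc(Cn2cnc3nc(Cl)nc(Cl)c32)c1` gives 2180 nM in this assay.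

Compound 3 arises from compound 1 through one change, (chloro in place of hydrogen on an aromatic carbon), and the step of no change at the digits printed from compound 1 to compound 3 (within the scatter) shows that this change leaves the read-out unchanged on the core of compound 1.

Compound 4 `ClCc1ccccc1Cn1cnc2nc(Cl)nc(Cl)c21` is not yet measured. It arises from compound 2 through (chloro in place of hydrogen on an aromatic carbon), and its place description matches that of the change from compound 1 to compound 3 word for word, so the two are the same change, applied to a different core. Because no change at the digits printed from compound 1 to compound 3 (within the scatter) was flat, compound 4 is expected to sit close to compound 2 in this assay, with a step of a 1.0-fold lower number from compound 2 to compound 4 (0.01 log units; within the scatter) estimated. Going by the values given here, that rests on one pair only, and the core of compound 2 has given no step of its own yet, so the range is kept wide. Compound 4 is therefore estimated at 11000 nM in this assay, between 4500 nM and 27000 nM.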

Compound 4, concentration for 50% growth inhibition: 2690 nM
Estimate against measurement, compound 4: 4.1-fold (0.61 log units) above, outside the stated range (below it).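

In this assay, the change of chloro in place of hydrogen on an aromatic carbon does not carry over from one core to the other with the same size of step: the same change on two cores in this assay, no change at the digits printed (within the scatter) from compound 1 to compound 3 and a 4.2-fold lower number (0.62 log units; beyond the scatter) from compound 2 to compound 4, 4.2-fold (0.62 log units) apart, beyond the scatter of two such steps. On the core of compound 2 the change gives a 4.2-fold lower number from compound 2 to compound 4 (0.62 log units; beyond the scatter), while on the core of compound 1 it gives no change at the digits printed from compound 1 to compound 3 (within the scatter), so the flat step on one core did not foretell the step on the other, and in this series a step read on one core cannot simply be transferred to the other. This does not show how the change would behave on any further core, nor what lies behind the gap, since it rests on two pairs, one substituent and one cell line.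

The compounds shown leave open whether another group on that same aromatic carbon, such as an amine or a methoxy group, would also depend on the core in this way. They also leave open what happens when the chloromethyl group gives way to a hydroxymethyl or a plain methyl group on either core, and whether the gap between the two steps appears in other cell lines.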